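The compounds below may be only part of what the source reports. "The series", "measured", "known", "first", "only" and "open" are said of these compounds alone.

Measured compounds:
- compound 1 `COc1cc(Cl)cc(-c2nn(-c3cccc(NC(=O)Nc4ccc(Cl)c(C(F)(F)F)c4)c3)cc2-c2ccncc2)c1`: -19.8%
- compound 2 `COc1cc(Cl)cc(-c2nn(-c3cccc(NC(=O)c4cc(C(F)(F)F)cc(C(F)(F)F)c4)c3)cc2-c2ccncc2)c1`: 104%
- compound 3 `COc1cc(Cl)cc(-c2nn(-c3cccc(NC(=O)c4ccc(Cl)c(Cl)c4)c3)cc2-c2ccncc2)c1`: 96.4%

In a functional assay on Malme-3M cells (Homo sapiens) for inhibition, read by sulforhodamine B assay, with a stated time of 48 h, tested at 10 uM (on this read-out lower numbers stand for a stronger effect and higher numbers for a weaker effect at the one concentration tested), compound 3 stands second highest of the three numbers shown. Its nearest neighbour is compound 2, whose value differs from it only within the usual scatter; compound 1 lies far below both. Going by the values given here, the one step among the measured compounds, a number 116.2 percentage points higher from compound 1 to compound 3 (beyond the scatter), is large, but it swaps a (4-chloro-3-(trifluoromethyl)phenyl)amino group for a 3,4-dichlorophenyl group, not one substituted phenyl for another.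

Compound 4 `COc1cc(Cl)cc(-c2nn(-c3cccc(NC(=O)c4cccc(C(F)(F)F)c4)c3)cc2-c2ccncc2)c1` differs from compound 3 by 3-(trifluoromethyl)phenyl in place of 3,4-dichlorophenyl on a carbonyl carbon. Among the compounds with values here, no measured step matches this change; the closest guide is that compound 2 and compound 3, both carrying a substituted phenyl on the carbonyl carbon, give values within the scatter of each other. A step within the scatter, a number 1.6 percentage points higher from compound 3 to compound 4 (within the scatter), is therefore expected. Compound 4 is estimated at 98%, with a range from 78% to 115%.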

Compound 4, a percentage reported as activity, at one concentration (the size of the read-out at that concentration, not a potency): 92.4%
Compound 4: middle estimate off by 5.6 percentage points, on the high side; the measured number falls inside the stated range.
By their numbers in this assay, from the lowest: compound 1; then compounds 4, 3 and 2 (each within the scatter of the next, the first and the last beyond it).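

In this assay, the 3-(trifluoromethyl)phenyl and 3,4-dichlorophenyl groups on the carbonyl carbon cannot be told apart (a number 4 percentage points lower from compound 3 to compound 4 (within the scatter)), while losing one trifluoromethyl group gives only a modest step (a number 11.6 percentage points lower from compound 2 to compound 4 (beyond the scatter)). Compound 4 remains far from the (4-chloro-3-(trifluoromethyl)phenyl)amino compound (a number 112.2 percentage points higher from compound 1 to compound 4 (beyond the scatter)), so a third substituted phenyl on this carbonyl carbon again falls well short of it. Nothing here explains these differences. Still open, on these data alone, is how an amine or a carboxylic acid on this phenyl would read out. Also open, as far as these compounds go, is whether a plain phenylamino group on the carbonyl carbon would approach compound 1.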